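Bromo in place of chloro: working notes

The source may hold more compounds than are shown below. What is called first, only, known or untested is meant among the compounds shown, and "the series" means these compounds.

Measured in an ADME assay on RAW264.7 cells (Mus musculus) for cytotoxicity, read by MTT assay, with a stated time of 48 h; on this read-out higher numbers stand for lower toxicity in this test and lower numbers for higher toxicity in this test:
- compound 1 `S=C(N/N=C\c1ccnc2ccccc12)Nc1ccccc1`: 118000 nM
- compound 2 `S=C(N/N=C\c1ccnc2ccccc12)Nc1ccc(Cl)cc1`: 63500 nM

Compound 2, at 63500 nM, stands within the scatter of compound 1. Compound 3 `S=C(N/N=C\c1ccnc2ccccc12)Nc1ccc(Br)cc1` is the next compound, with this change: bromo in place of chloro on an aromatic carbon. That is bromo in place of chloro on an aromatic carbon, para to a large group. Going by the values given here, the only measured step bearing on it is a 1.9-fold lower number from compound 1 to compound 2 (0.27 log units; within the scatter), for chloro in place of hydrogen on an aromatic carbon. No step beyond the scatter is therefore expected in this assay, in either direction. The expected step is a 1.1-fold lower number from compound 2 to compound 3 (0.02 log units; within the scatter). For compound 3 the estimated value is 60000 nM, with an expected range of 30000 nM to 120000 nM.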

Compound 3, half-maximal cytotoxic concentration: 53500 nM
The estimate for compound 3 lay 1.1-fold (0.05 log units) above the measured number; the measured number falls inside the stated range.
By their numbers in this assay, from the lowest: compounds 3, 2 and 1 (each within the scatter of the next, the first and the last beyond it).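

In this assay, the change from 4-chlorophenyl to 4-bromophenyl gives a 1.2-fold lower number from compound 2 to compound 3 (0.07 log units; within the scatter), so the two halogens are not separated at this position. Bromo in place of hydrogen gives a 2.2-fold lower number from compound 1 to compound 3 (0.34 log units; beyond the scatter), the only step at this position that lies beyond the scatter, and a modest one. Nothing on hand points to a cause for either step.

Whether this step is specific to halogens remains open, since an amine, a carboxylic acid or a methoxy group at this place is not among the compounds shown.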